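A few compounds are considered here, and "the series" means these few. Any claim that something is new, unique, unknown or untested is made for them only; others in the source may bear on it.

Measured so far in a functional assay on MCF7 cells (Homo sapiens) for antiproliferative activity; on this read-out higher numbers stand for weaker inhibition and lower numbers for stronger inhibition:
compound 1 `O=c1oc2cc(O)ccc2c(-c2ccc(OCCCCCN3CCCCC3)cc2)c1-c1ccccc1` gives 335 nM
compound 2 `O=c1oc2cc(O)ccc2c(-c2ccc(OCCCCCCN3CCCCC3)cc2)c1-c1ccccc1` gives 720 nM

Within the data shown here, compound 2 holds the higher of the two numbers and is therefore the weaker inhibitor of the pair, and its only neighbour is compound 1 at 335 nM on this read-out. Compound 3 `O=c1oc2cc(O)ccc2c(-c2ccc(OCCCN3CCCCC3)cc2)c1-c1ccccc1` has not yet been measured. The change from compound 2 is piperidin-1-yl in place of 3-(piperidin-1-yl)propyl on a saturated chain carbon, three bonds along the chain from an oxygen on an aromatic ring in which piperidin-1-yl takes the place of 3-(piperidin-1-yl)propyl on a saturated chain carbon, three bonds along the chain from an oxygen on an aromatic ring.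

Among the measured compounds shown here, only one measured step bears on this: a 2.1-fold higher number from compound 1 to compound 2 (0.33 log units; beyond the scatter) came with (piperidin-1-yl)methyl in place of piperidin-1-yl on the same chain. That step was modest. Compound 3 goes the opposite way along the chain and further, so a lower number than for compound 2 is expected. A single step cannot show how far this trend runs, and no shorter chain has been measured. The expected change is a 2.9-fold lower number from compound 2 to compound 3 (0.46 log units; beyond the scatter) in this assay as estimated here. For compound 3 the estimated value is 250 nM with an expected range from 80 nM to 800 nM in this read-out.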

Compound 3, half-maximal inhibitory concentration: 335 nM
Compound 3: middle estimate off by 1.3-fold (0.13 log units), on the low side; measured number inside the range.
By their numbers in this assay, from the lowest: compounds 1 and 3 (each within the scatter of the next); then compound 2.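

In this assay, among these compounds, the step of a 2.1-fold lower number from compound 2 to compound 3 (0.33 log units; beyond the scatter) shows that removing 3-(piperidin-1-yl)propyl in favour of piperidin-1-yl, on a saturated chain carbon three bonds along the chain from an oxygen on an aromatic ring, is tied to a real difference, which the single earlier step could only suggest. The other new step, no change at the digits printed from compound 1 to compound 3 (within the scatter), shows that the number does not keep falling as the chain shortens: compound 2 stands apart, while compound 1 and compound 3 cannot be told apart, and compound 3 goes against any steady trend with chain length across these three compounds. No measurement is available that would explain this flat stretch followed by the rise at compound 2.

As far as these compounds go, it remains open whether a chain shorter than that of compound 3 or longer than that of compound 2 would continue this picture. From the compounds shown here alone, it is also open whether the same chain-length profile would hold if the piperidine ring gave way to another amine, such as morpholine or dimethylamine.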